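The compounds below may be only part of what the source reports. "The series", "measured", "known", "first", "only" and "open" are said of these compounds alone.

In a functional assay on MDA-MB-231 cells (Homo sapiens) for cytotoxicity, read by MTT assay, with a stated time of 72 h (on this read-out higher numbers stand for weaker inhibition and lower numbers for stronger inhibition), three compounds sharing one core have been measured. Compound 2 `COc1ccc(/C(=C(/CCNC(=O)NCc2ccccc2)c2ccccc2)c2ccccc2)cc1`, which carries benzylamino on a carbonyl carbon, gives > 50000 nM, a limit of the assay and not a number. Compound 1 `CCOC(=O)C(=O)NCC/C(=C(\c1ccccc1)c1ccc(OC)cc1)c1ccccc1`, with ethoxycarbonyl in that place, gives > 50000 nM, also a limit. Within the data shown here, compound 3 `COc1ccc(/C(=C(/CCNC(=O)N2CCOCC2)c2ccccc2)c2ccccc2)cc1`, with morpholin-4-yl there, gives 42800 nM, the one actual number so far. Compound 2 therefore stands with compound 1 at the limit of > 50000 nM in this assay, at which 2 of the 3 values shown sit.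

Compound 4 `CCN(CC)C(=O)NCC/C(=C(\c1ccccc1)c1ccc(OC)cc1)c1ccccc1` has diethylamino in place of benzylamino on the same carbonyl carbon: diethylamino in place of benzylamino on a carbonyl carbon. The closest measured change is an at least 1.1-fold lower number from compound 2 to compound 3 (0.06 log units; that floor lies within the scatter), which also replaces benzylamino. The other readable one is an at least 1.1-fold lower number from compound 1 to compound 3 (0.06 log units; that floor lies within the scatter), and the remaining one is a step that the two limits leave unreadable from compound 1 to compound 2. None of these shows a change beyond the scatter. With compound 3 at 42800 nM, no step beyond the scatter is expected in this assay. For compound 4, a further limit is about as likely as a number. The estimated step, no larger than the scatter, is an at least 1.1-fold lower number from compound 2 to compound 4 (0.04 log units; that floor lies within the scatter). For compound 4 the expected value is 45000 nM, with an estimated range of 20000 nM to 90000 nM.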

Compound 4, half-maximal inhibitory concentration: 40700 nM
Estimate against measurement, compound 4: 1.1-fold (0.04 log units) above, and the stated range covers the measured number.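

In this assay this position now carries two actual numbers rather than one, and the step between them is a 1.1-fold lower number from compound 3 to compound 4 (0.02 log units; within the scatter), so diethylamino and morpholin-4-yl on a carbonyl carbon cannot be told apart here. The two steps that start from a limit are an at least 1.2-fold lower number from compound 2 to compound 4 (0.08 log units; that floor lies within the scatter) and an at least 1.2-fold lower number from compound 1 to compound 4 (0.08 log units; that floor lies within the scatter); neither floor leaves the scatter, so neither the exchange of benzylamino, with its aromatic ring and hydrogen-bond donor, for the ringless diethylamino nor the exchange of ethoxycarbonyl for diethylamino shows a readable change. Compound 1 and compound 2 remain limits of the assay and not numbers, which keeps their true distance from the other two compounds unknown: the limit of > 50000 nM in this assay, at which 2 of the 4 values shown sit.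

On these data alone, what stays open is how far compound 1 and compound 2 actually lie from the two measured compounds, and whether any group on this carbonyl carbon can move the number beyond the scatter. A piperazin-1-yl group, with a second ring nitrogen in place of the morpholine oxygen, or a dimethylamino group, shorter than diethylamino, would test this position further.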